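Ethenyl dimethylamide in place of a saturated methylamide chain

The source may hold more compounds than are shown below. What is called first, only, known or untested is meant among the compounds shown, and "the series" means these compounds.

Compound 2 `CNC(=O)CCc1ccncc1-c1ccc2ccccc2c1` was tested in a functional assay on HCT-116 cells (Homo sapiens) for inhibition, read by MTT assay, with a stated time of 72 h (a higher number here means a weaker inhibitor of growth, a lower number a stronger inhibitor of growth), where compound 2 gives 19300 nM. Compound 3 `CNC(=O)/C=C/c1ccncc1-c1ccc2c(ccn2C)c1` gives 4450 nM in this assay, a lower number than compound 2 by more than the usual scatter, so compound 2 stands as the highest of the two reported numbers. For compound 1 `COC1CN(C(=O)/C=C/c2ccncc2-c2ccc3[nH]ncc3c2)C1` the entry in this assay is "not determined" (no result reported). Compound 4 `CN(C)C(=O)/C=C/c1ccncc1-c1ccc2ccccc2c1` differs from compound 2 in one place: 2-(dimethylcarbamoyl)ethenyl in place of 2-(methylcarbamoyl)ethyl on an aromatic carbon. Within the data shown here, no measured pair differing in one place is available, so the size of this step is unknown. Compound 3 carries the ethenyl chain and gives 4450 nM, which points to a fall beyond the scatter. The expected step is a 2.8-fold lower number from compound 2 to compound 4 (0.44 log units; beyond the scatter). Compound 4 is estimated at 7000 nM, within a range from 2500 nM to 20000 nM.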

Compound 4, concentration for 50% growth inhibition: 4540 nM
Compound 4: the middle estimate sits 1.5-fold (0.19 log units) above what was measured; the measured number falls inside the stated range.
By their numbers in this assay, from the lowest: compounds 3 and 4 (each within the scatter of the next); then compound 2.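

In this assay, placing 2-(dimethylcarbamoyl)ethenyl in place of 2-(methylcarbamoyl)ethyl on the aromatic carbon opposite the ring nitrogen gives a 4.3-fold lower number from compound 2 to compound 4 (0.63 log units; beyond the scatter), so the chain at this position bears on growth inhibition. The entering chain has 0 hydrogen-bond donors, so the amide hydrogen is not required for the lower number. No measurement on hand explains the step.

As far as these compounds go, the double bond and the added methyl change together, so their separate shares remain open. Also open, from the compounds shown here alone, is how a longer chain, an amine or a carboxylic acid would read at this position.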